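This account rests on a few compounds, and the source may have more. Where it says the series, first, only, none or still open, it means among the compounds named here.

Compound 1 `CCC(=O)OC[C@H]1O[C@@H](O[C@@H]2OC=C(C(=O)OC)[C@H]3C[C@H](OC(C)=O)[C@H](C)[C@@H]23)[C@H](OC(C)=O)[C@@H](OC(C)=O)[C@@H]1OC(C)=O`: 2.85 ug/mL
Compound 2 `C=CC(=O)OC[C@H]1O[C@@H](O[C@@H]2OC=C(C(=O)OC)[C@H]3C[C@H](OC(C)=O)[C@H](C)[C@@H]23)[C@H](OC(C)=O)[C@@H](OC(C)=O)[C@@H]1OC(C)=O`: "not active" (no number reported)

Both compounds were tested in a functional assay on Caco-2 cells (Homo sapiens) for cytotoxicity, read by MTT assay, with a stated time of 4 h; a higher number here means a weaker inhibitor, a lower number a stronger inhibitor. There compound 1 gives a number (2.85 ug/mL) whereas compound 2 is recorded as "not active" (no number reported) and so has no single figure to stand on. Compound 3 `COC(=O)C1=CO[C@@H](O[C@@H]2O[C@H](COC(=O)c3cccc([N+](=O)[O-])c3)[C@@H](OC(C)=O)[C@H](OC(C)=O)[C@H]2OC(C)=O)[C@@H]2[C@@H](C)[C@@H](OC(C)=O)C[C@H]12` has not yet been measured. The structural change is 3-nitrophenyl in place of vinyl on a carbonyl carbon and it amounts to 3-nitrophenyl in place of vinyl on a carbonyl carbon. Within the data shown here, no measured step covers this exchange, and with no number for compound 2 the size of the step in this assay cannot be read from the data. The expectation is therefore loose: compound 3 should give a measurable value somewhat weaker than that of compound 1 (2.85 ug/mL) with a real chance that no number is reported. Compound 3 is estimated at 6 ug/mL (expected range 1.5 ug/mL to 30 ug/mL).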

Compound 3, half-maximal inhibitory concentration: 1 ug/mL
Compound 3: the middle estimate sits 6.0-fold (0.78 log units) above what was measured; the whole stated range lies above it.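

In this assay, 3-nitrophenyl on this carbonyl carbon gives a lower number than ethyl, a 2.9-fold lower number from compound 1 to compound 3 (0.45 log units; beyond the scatter), so the position takes an aromatic ring without loss and with a modest gain. Compound 2, with vinyl at the same place, is recorded as not active, whereas compound 3 gives 1 ug/mL; the step between them cannot be read, as one side has no number. Nothing measured here explains either difference.

The compounds shown leave open whether the aromatic ring or its nitro group accounts for the step, a question that plain phenyl or 3-aminophenyl on the same carbonyl carbon would address. They also leave open how a longer chain, such as butyl, would compare with ethyl at this place.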